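The compounds below may be only part of what the source reports. "The series", "measured", "known", "first", "only" and "open" are said of these compounds alone.

Three compounds share one core and differ only in the group attached to the amide-type nitrogen. Compound 1 `N#Cc1ccc(NC(=S)N/N=C/c2ccc3ccccc3n2)cc1` gives 23700 nM in a functional assay on SGC-7901 cells (Homo sapiens) for antiproliferative activity, read by sulforhodamine B assay, with a stated time of 72 h; on this read-out lower numbers stand for stronger inhibition and higher numbers for weaker inhibition. Compound 2 `S=C(N/N=C/c1ccc2ccccc2n1)Nc1ccccc1` gives 26500 nM, and compound 3 `Fc1ccc(NC(=S)N/N=C/c2ccc3ccccc3n2)cc1` gives 32300 nM. Compound 3 sits alongside the other two, since the steps of a 1.4-fold higher number from compound 1 to compound 3 (0.13 log units; within the scatter) and a 1.2-fold higher number from compound 2 to compound 3 (0.09 log units; within the scatter), like a 1.1-fold higher number from compound 1 to compound 2 (0.05 log units; within the scatter), stay within the scatter. Compound 4 `COc1ccccc1NC(=S)N/N=C/c1ccc2ccccc2n1` carries the change (2-methoxyphenyl in place of 4-fluorophenyl on an amide-type nitrogen). Among the compounds with values here, every measured step so far swapped one group on that same ring and barely moved the number, so compound 4 is expected to show a step of a 1.2-fold lower number from compound 3 to compound 4 (0.06 log units; within the scatter) in this assay, not beyond the scatter. Compound 4 is therefore estimated at 28000 nM, with a range from 12000 nM to 65000 nM.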

Compound 4, half-maximal inhibitory concentration: > 100000 nM
Compound 4 gave a limit, no number (the forecaster's own chance of this, stated with the estimate: 10%); at least 3.5-fold (0.55 log units) between middle value and limit.
By their numbers in this assay, from the lowest: compounds 1, 2 and 3 (each within the scatter of the next). At a limit, above all of these: compound 4.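

The amide-type nitrogen does not accept every aromatic group equally: in this assay, the 2-methoxyphenyl group gives an at least 3.0-fold higher number from compound 3 to compound 4 (0.49 log units; beyond the scatter), an at least 3.7-fold higher number from compound 2 to compound 4 (0.57 log units; beyond the scatter) and an at least 4.2-fold higher number from compound 1 to compound 4 (0.62 log units; beyond the scatter), all beyond the scatter, whereas exchanging hydrogen, fluoro and cyano left the numbers within it. Compound 4 gave a limit rather than a number: the limit of > 100000 nM in this assay, at which 1 of the 4 values shown sits. These steps therefore have a lower bound but no upper one.

As far as these compounds go, it remains open whether the drop belongs to methoxy itself or to where it sits on the ring. From the compounds shown here alone, how an amine or a carboxylic acid on that ring would behave also remains open.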